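Swapping the aryl group on a shared amide core

The source may hold more compounds than are shown below. What is called first, only, known or untested is meant among the compounds shown, and "the series" means these compounds.

Compound 1 `COc1ccc(-c2ccnc(C(=O)Nc3ccc(Oc4ccnc5[nH]ccc45)cc3)c2)cc1`: 6970 nM
Compound 2 `Cc1cccc(-c2ccnc(C(=O)Nc3ccc(Oc4ccnc5[nH]ccc45)c(F)c3)c2)c1`: 1750 nM
Compound 3 `Cc1ccc(-c2ccnc(C(=O)Nc3ccc(Oc4ccnc5[nH]ccc45)c(F)c3)c2)c(C)c1`: 4350 nM

In a functional assay on A549 cells (Homo sapiens) for cytotoxicity, read by MTT assay, with a stated time of 72 h (a lower number here means a stronger inhibitor, a higher number a weaker inhibitor), compound 3 stands second highest of the three numbers; compound 1 lies within the scatter of it, while compound 2 lies beyond it. For the measured compounds named here, the one measured step that touches the aryl group, a 2.5-fold higher number from compound 2 to compound 3 (0.40 log units; beyond the scatter), was modest. Compound 4 `COc1ccc(-c2ccnc(C(=O)Nc3ccc(Oc4ccnc5[nH]ccc45)c(F)c3)c2)cc1` differs from compound 3 by 4-methoxyphenyl in place of 2,4-dimethylphenyl on an aromatic carbon. Going by the values given here, compound 1 carries the same 4-methoxyphenyl but no fluorine, and its number and that of compound 3 sit within the scatter of each other; no measured step isolates either change on its own. For compound 4 a small shift is therefore expected in this assay, a 1.1-fold higher number from compound 3 to compound 4 (0.06 log units; within the scatter). Compound 4 is estimated at 5000 nM, with a range from 2000 nM to 14000 nM.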

Compound 4, half-maximal inhibitory concentration: 1040 nM
Estimate against measurement, compound 4: 4.8-fold (0.68 log units) above; measured number outside the range, below it.
By their numbers in this assay, from the lowest: compounds 4 and 2 (each within the scatter of the next); then compounds 3 and 1 (each within the scatter of the next).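

In this assay the aryl group at this position can shift the number beyond the scatter: 4-methoxyphenyl in place of 2,4-dimethylphenyl gives a 4.2-fold lower number from compound 3 to compound 4 (0.62 log units; beyond the scatter) and in place of 3-methylphenyl gives a 1.7-fold lower number from compound 2 to compound 4 (0.23 log units; within the scatter) so only the first swap is a real difference. For the compounds shown here, with 4-methoxyphenyl held fixed, fluoro in place of hydrogen gives a 6.7-fold lower number from compound 1 to compound 4 (0.83 log units; beyond the scatter) and this is the first measured step that isolates the fluorine. Nothing available explains either change.

On these data alone, whether the fluorine has a similar effect alongside other aryl groups remains open. So does the effect of an amine or a carboxylic acid on this aryl ring.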